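This account rests on a few compounds, and the source may have more. Where it says the series, first, only, none or still open, it means among the compounds named here.

In a functional assay on MCF7 cells (Homo sapiens) for antiproliferative activity, read by MTT assay (a higher number here means a weaker inhibitor, a lower number a stronger inhibitor), compound 1 `NS(=O)(=O)c1ccc(/N=C2\NC(=O)/C(=C3/C(=O)Nc4ccc(Cl)cc43)S2)cc1` gives 3960 nM. Compound 2 `Cc1cc(C)c2c(c1)/C(=C1/S/C(=N/c3ccc(S(N)(=O)=O)cc3)NC1=O)C(=O)N2` reads > 200000 nM, which is a limit of the assay and not a number. Compound 3 `Cc1ccc2c(c1)/C(=C1/S/C(=N/c3ccc(S(N)(=O)=O)cc3)NC1=O)C(=O)N2` differs from compound 2 by one change, hydrogen in place of methyl on an aromatic carbon. For the measured compounds named here, no measured step isolates this change, so the expectation rests on compound 1, whose 3960 nM shows that the series can give a measurable value. The step of an at least 8.0-fold lower number from compound 2 to compound 3 (0.90 log units; beyond the scatter) is expected to be large and towards stronger inhibition, beyond the scatter. Compound 3 is estimated at 25000 nM, with an expected range of 4000 nM to 150000 nM.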

Compound 3, half-maximal inhibitory concentration: > 200000 nM
Compound 3 ended at the assay's limit; the forecaster's own chance of this, stated with the estimate: 20%; middle value at least 8.0-fold (0.90 log units) from the limit.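

Compound 3 reads > 200000 nM in this assay, which is a limit of the assay and not a number. Methyl in place of chloro on an aromatic carbon gives an at least 50-fold higher number from compound 1 to compound 3 (1.70 log units; beyond the scatter), so at this position the chloro of compound 1 gives the only measurable value shown. The step for hydrogen in place of methyl cannot be read, because both of its ends are limits: the limit of > 200000 nM in this assay, at which 2 of the 3 values shown sit.

On these data alone, whether a measurable value at this position is special to chloro stays open. A bromo, a methoxy or an amine there would test this in this assay.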